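Shortening the Link to the Cyclohexyl Ring

This account rests on a few compounds, and the source may have more. Where it says the series, first, only, none or still open, it means among the compounds named here.

Compound 3 `O=C(O)c1ccccc1-c1ccc(CCc2ncc(CC3CCCCC3)[nH]2)cc1` gives the lowest number of the three compounds in an in vitro functional assay on cells for agonist activity at Bombesin receptor subtype-3 (Homo sapiens), read by luminescence and calcium flux (a higher number here means that more compound is needed for the effect, a lower number that less compound is needed), namely 41 nM. Among the measured compounds shown here, compound 1 `CCCCc1cnc(C(CCCO)Cc2ccc(-c3ccccc3C(=O)O)cc2)[nH]1` gives 1900 nM, and compound 2 `CCCCc1cnc(C(CCCC)Cc2ccc(-c3ccccc3C(=O)O)cc2)[nH]1` gives 2660 nM; the step of a 1.4-fold higher number from compound 1 to compound 2 (0.15 log units; within the scatter) is the only measured single change. Compound 4 `O=C(O)c1ccccc1-c1ccc(CCc2ncc(C3CCCCC3)[nH]2)cc1` differs from compound 3 by cyclohexyl in place of cyclohexylmethyl on an aromatic carbon. For the measured compounds named here, no measured step touches this kind of change: the step from compound 1 to compound 2 swaps a group at the end of a chain and stays within the scatter, so it says little about shortening the link to a ring. A modest loss is therefore expected, a 2.4-fold higher number from compound 3 to compound 4 (0.39 log units; beyond the scatter). Compound 4 is estimated at 100 nM, within 30 nM to 400 nM.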

Compound 4, half-maximal effective concentration: 375 nM
Compound 4: the middle estimate sits 3.8-fold (0.57 log units) below what was measured; the range from low to high includes it.
By their numbers in this assay, from the lowest: compound 3; then compound 4; then compounds 1 and 2 (each within the scatter of the next).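

Trading cyclohexylmethyl for cyclohexyl on this aromatic carbon of the five-membered ring gives, in this assay, a 9.1-fold higher number from compound 3 to compound 4 (0.96 log units; beyond the scatter). Unlike the earlier change at the end of a chain, this one moves the number clearly, so this position responds even when the ring stays and only its link is shortened. No measured evidence is available to explain the loss. Among the compounds shown here, these compounds show only two link lengths, leaving open what cyclohexylethyl, with its longer chain, would do here. A phenyl ring in place of the cyclohexyl ring also remains untested among the compounds shown.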